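The compounds below may be only part of what the source reports. "The series", "measured", "known", "first", "only" and "open" are said of these compounds alone.

In a functional assay on K562 cells (Homo sapiens) for inhibition, read by trypan blue exclusion, with a stated time of 72 h (a lower number here means a stronger inhibitor, a higher number a weaker inhibitor), compound 1 (`Cn1c(=O)c(S(=O)(=O)c2ccc(F)cc2F)cc2cnc(Nc3ccc4[nH]c(C(=O)O)cc4c3)nc21`) gives 10000 nM and compound 2 (`COC(=O)Cn1c(=O)c(S(=O)(=O)c2ccc(F)cc2F)cc2cnc(Nc3ccc4[nH]ccc4c3)nc21`) gives 5000 nM while compound 3 (`Cn1c(=O)c(S(=O)(=O)c2ccc(Cl)cc2Cl)cc2cnc(Nc3ccc4[nH]ccc4c3)nc21`) gives 1000 nM as the lowest number of the three. Compound 3 is therefore the strongest inhibitor so far, and its gaps to both of the others lie beyond the usual scatter. Compound 4 (`Cn1c(=O)c(S(=O)(=O)c2ccc(C(=O)O)cc2)cc2cnc(Nc3ccc4[nH]ccc4c3)nc21`) has not yet been measured. It carries 4-carboxyphenyl in place of 2,4-dichlorophenyl on a sulfonyl sulfur and is otherwise the same as compound 3. Within the data shown here, no two measured compounds differ in only one place, so no measured step speaks directly to this change. The closest hint is loose: compound 1 also carries a carboxy group, though elsewhere in its structure, and it gives 10000 nM as the highest number. A weakening beyond the scatter is therefore expected, with an estimated size of a 6.0-fold higher number from compound 3 to compound 4 (0.78 log units; beyond the scatter) in this assay overall. Compound 4 is estimated at 6000 nM with an expected range from 2000 nM to 20000 nM when measured.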

Compound 4, half-maximal inhibitory concentration: 5000 nM
Compound 4: the middle estimate sits 1.2-fold (0.08 log units) above what was measured; the measured number falls inside the stated range.
By their numbers in this assay, from the lowest: compound 3; then compounds 2, 4 and 1 (each within the scatter of the next).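

Putting 4-carboxyphenyl in place of 2,4-dichlorophenyl on a sulfonyl sulfur gives a 5.0-fold higher number from compound 3 to compound 4 (0.70 log units; beyond the scatter) in this assay. Among these compounds, this is the first step in the set that changes only one place, and it shows that the number in this assay responds to what this sulfonyl sulfur carries. The step swaps the two chlorines and the carboxy group at once, so it cannot say how much each contributes, and nothing measured here explains the change.

The compounds shown leave open whether the rise follows from losing the chlorines or from gaining the carboxy group. A plain phenyl on the sulfonyl sulfur would speak to the first question, and a methyl ester in place of the carboxylic acid would speak to the second.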